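Amide substituent swap from a limit in the cell assay

The source may report more compounds than this note shows. Statements on the series, on what has been measured and on what is new or still open speak of the compounds shown alone.

Measured so far:
compound 1 `COc1cccc(OC)c1C(=O)Nc1c[nH]nc1C(=O)Nc1ccncc1` — > 50000 nM
compound 2 `CCc1ccccc1C(=O)Nc1c[nH]nc1C(=O)N[C@H]1CC[C@H](OC)CC1` — 3400 nM

In an ADME assay on MRC5 cells (Homo sapiens) for inhibition, with a stated time of 72 h (on this read-out higher numbers stand for an effect only at larger amounts of compound and lower numbers for an effect already at smaller amounts), compound 1 stands only at a limit, (the limit of > 50000 nM in this assay, at which 1 of the 2 values shown sits), so no number is known for it. Compound 2 gives 3400 nM in this assay. Compound 3 `COc1cccc(OC)c1C(=O)Nc1c[nH]nc1C(=O)NCC1CCCCC1` differs from compound 1 by cyclohexylmethyl in place of pyridin-4-yl on an amide-type nitrogen. Because compound 1 sits at the limit of > 50000 nM in this assay, at which 1 of the 2 values shown sits, the step to compound 3 can only hold at the limit or move toward smaller amounts; a move beyond the scatter toward smaller amounts is expected, with a fair chance that only a limit is reported again. Compound 3 is expected near 20000 nM, within 6000 nM to 50000 nM. The expected step is an at least 2.5-fold lower number from compound 1 to compound 3 (0.39 log units; beyond the scatter).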

Compound 3, half-maximal effective concentration: > 50000 nM
Compound 3: only a limit was reported; the forecaster's own chance of this, stated with the estimate: 40%; middle value at least 2.5-fold (0.39 log units) from the limit.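

No step can be read between compound 1 and compound 3, since both stand only at a limit: the limit of > 50000 nM in this assay, at which 2 of the 3 values shown sit. Left open is whether cyclohexylmethyl in place of pyridin-4-yl on an amide-type nitrogen shifts the read-out at all.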